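Swapping Methoxy for Cyano: Expected Cytotoxicity of Compound 3

A few compounds are considered here, and "the series" means these few. Any claim that something is new, unique, unknown or untested is made for them only; others in the source may bear on it.

Compound 1, `c1ccc(CCSCc2cnc3ccc(-c4ccccc4)cn23)cc1`, gives 4 ug/mL in an ADME assay on HEL cells (Homo sapiens) for cytotoxicity, with a stated time of 3 days; on this read-out higher numbers stand for lower toxicity in this test and lower numbers for higher toxicity in this test.
Compound 2, `COc1cccc(-c2cc(C)c3ncc(CSCCc4ccccc4)n3c2)c1`, gives 20 ug/mL in this assay.

Of the two measured compounds, compound 2 stands with the higher number in this assay, and compound 1 sits below it by a gap that lies beyond the usual scatter. These two compounds differ in more than one place, so their values alone cannot be tied to any single change.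

Compound 3, `Cc1cc(-c2cccc(C#N)c2)cn2c(CSCCc3ccccc3)cnc12`, is not yet measured. It differs from compound 2 in one place only: cyano in place of methoxy on an aromatic carbon. For the measured compounds named here, no measured pair shows this exact change, so there is no direct precedent for its effect in this assay. Given a change of two heavy atoms with no change in ring count, the step of no change at the digits printed from compound 2 to compound 3 (within the scatter) is expected to be small, not beyond the usual scatter. Compound 3 is therefore estimated at 20 ug/mL, with a plausible range from 7 ug/mL to 60 ug/mL.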

Compound 3, minimum cytotoxic concentration: > 100 ug/mL
Compound 3 gave a limit, no number; the forecaster's own chance of this, stated with the estimate: 10%; middle value at least 5.0-fold (0.69 log units) from the limit.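

In this assay, putting cyano in place of methoxy gives an at least 5.0-fold higher number from compound 2 to compound 3 (0.69 log units; beyond the scatter), which here points to lower toxicity in this test. For compound 3, the reading of > 100 ug/mL is a limit of the assay and not a number: the limit of > 100 ug/mL in this assay, at which 1 of the 3 values shown sits. Compounds 1 and 2 differ in more than one place and could not isolate any single group, whereas this pair shows that the group on this aromatic ring, meta to a large group, can move the read-out beyond the scatter, even though methoxy and cyano match in heavy atoms and hydrogen-bond acceptors.

The compounds shown leave open why the change has this effect and whether other groups at this place, such as an amine or a carboxylic acid, would act in the same direction. They also leave open whether the same swap would have a similar effect on the core of compound 1.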